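This account rests on a few compounds, and the source may have more. Where it says the series, first, only, none or still open, it means among the compounds named here.

Measured so far:
compound 1, `CC[C@H](C)[C@H](N)CN(C(=O)[C@@H]1C[C@H]1c1ccccc1)c1ccc(-c2ccccc2)cc1`: 230 nM; 800 nM (2 entries)
compound 2, `CC[C@H](C)[C@H](N)CN(C(=O)[C@@H]1C[C@H]1C1CCCCC1)c1ccc(-c2ccccc2)cc1`: > 25000 nM
compound 3, `CC(C)C[C@H](N)CN(C(=O)[C@@H]1C[C@H]1c1ccccc1)c1ccc(-c2cccnc2)cc1`: 10000 nM

In a functional assay for agonist activity at G protein-coupled receptor 88 (Homo sapiens), read by HTRF and cAMP accumulation (a higher number here means that more compound is needed for the effect, a lower number that less compound is needed), compound 1 gives 230 nM; 800 nM (2 entries), recorded as the several entries of compound 1 in this assay, 230 nM; 800 nM (2 entries). Compound 2 reaches only the limit of this assay, > 25000 nM, so no number is known for it; this is the limit of > 25000 nM in this assay, at which 1 of the 3 values shown sits. Compound 3 gives 10000 nM in this assay. It therefore stands at the weak end of the numbers shown: the reading of compound 1 is far lower, while compound 2 offers no number at all. Among the compounds with values here, compound 3 and compound 1 differ in more than one place, so no single step between them is counted.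

Compound 4, `CC(C)C[C@H](N)CN(C(=O)[C@@H]1C[C@H]1c1ccccc1)c1ccc(-c2ccc(Cl)cc2)cc1`, differs from compound 3 in one place: 4-chlorophenyl in place of pyridin-3-yl on an aromatic carbon. Within the data shown here, no measured pair reports this exchange, so what follows is an expectation only. Compound 4 is expected to give 1200 nM in this assay, in a range from 250 nM to 6000 nM. That estimate means a step of an 8.3-fold lower number from compound 3 to compound 4 (0.92 log units; beyond the scatter), expected to run toward lower values and beyond the usual scatter, a direction suggested by compound 1, which reads 230 nM; 800 nM (2 entries) without a pyridin-3-yl group, though compound 1 also carries a different side chain.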

Compound 4, half-maximal effective concentration: 640 nM
Estimate against measurement, compound 4: 1.9-fold (0.27 log units) above; the range from low to high includes it.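

Compound 3 and compound 4 form the first pair shown that differs in one place, and they show that the group on this aromatic carbon, para to a large group, matters strongly: in this assay, putting 4-chlorophenyl in place of pyridin-3-yl gives a 16-fold lower number from compound 3 to compound 4 (1.19 log units; beyond the scatter). The exchange alters two things at once, since the ring nitrogen with its hydrogen-bond acceptor leaves while a chlorine enters on a ring of carbon only, so this single step cannot be assigned to either alteration alone. Nothing in the data shown accounts for the size of this step.

The compounds shown leave open how a plain phenyl group, a 4-fluorophenyl group, a 4-methoxyphenyl group or a pyridin-4-yl group would read at this place on the side chain shared by compound 3 and compound 4, which would help separate the loss of the ring nitrogen from the gain of the chlorine. They also leave open whether the same exchange would produce a step of similar size on the side chain of compound 1.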